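A few compounds are considered here, and "the series" means these few. Any claim that something is new, unique, unknown or untested is made for them only; others in the source may bear on it.

Measured so far:
compound 1 `COC(=O)Nc1cc(-c2cc(C)c(OC[C@@](C)(N)CC(C)C)cn2)ccn1` — 1.4 nM
compound 2 `Cc1cc(-c2cc(Cl)c(OC[C@@](C)(N)CC(C)C)cn2)ccn1` — 0.7 nM
compound 3 `Cc1cc(-c2cc(C)c(OC[C@@](C)(N)CC(C)C)cn2)ccn1` — 4.7 nM

In an assay on brain (strain C57BL6) for displacement of a labelled ligand from AP2-associated protein kinase 1 (Mus musculus), read by scintillation counting, with a stated time of 1 h (a lower number here means a stronger inhibitor, a higher number a weaker inhibitor), compound 3 gives the highest number of the three, with compound 1 the nearest and compound 2 the furthest. Compound 4 `Cc1cc(-c2ccnc(C(F)F)c2)ncc1OC[C@@](C)(N)CC(C)C` differs from compound 3 by difluoromethyl in place of methyl on an aromatic carbon, on an aromatic carbon of a six-membered aromatic ring with one nitrogen, next to the ring nitrogen and meta to a large group. For the measured compounds named here, only the step of a 3.4-fold higher number from compound 1 to compound 3 (0.53 log units; beyond the scatter) touches this place; the step of a 6.7-fold higher number from compound 2 to compound 3 (0.83 log units; beyond the scatter) changes another ring and is not directly comparable. Going by the values given here, no measured pair covers difluoromethyl against methyl, so the expectation rests on that single step. Compound 4 is therefore estimated at 2.5 nM (range 0.8 nM to 8 nM), a modest expected lowering of a 1.9-fold lower number from compound 3 to compound 4 (0.27 log units; within the scatter) in this assay.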

Compound 4, inhibition constant: 0.3 nM
For compound 4 the middle estimate is 8.3-fold (0.92 log units) above the measured one; measured number below the stated range.
By their numbers in this assay, from the lowest: compound 4; then compounds 2 and 1 (each within the scatter of the next); then compound 3.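

In this assay, difluoromethyl on this aromatic carbon next to the ring nitrogen gives a 16-fold lower number from compound 3 to compound 4 (1.19 log units; beyond the scatter), a large step for a swap at a single place. The same group also gives a 4.7-fold lower number from compound 1 to compound 4 (0.67 log units; beyond the scatter), so at this place difluoromethyl goes beyond the (methoxycarbonyl)amino group, which had already given a lower number than methyl. Nothing measured here accounts for either step.

Still open, on these data alone, is how trifluoromethyl or a nitrile would read at this place, and whether difluoromethyl gives a comparable step alongside the chloro of compound 2.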